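The source may report more compounds than this note shows. Statements on the series, on what has been measured and on what is new or still open speak of the compounds shown alone.

Compound 1, `COCCNC(=O)Nc1cc2c(Nc3ccc(F)c(Cl)c3)ncnc2cc1O[C@H]1CCOC1`, gives 387 nM in a functional assay on A-431 cells (Homo sapiens) for antiproliferative activity, read by sulforhodamine B assay, with a stated time of 72 h; a lower number here means a stronger inhibitor, a higher number a weaker inhibitor. Compound 2, `CN(C)CCNC(=O)Nc1cc2c(Nc3ccc(F)c(Cl)c3)ncnc2cc1O[C@H]1CCOC1`, gives 806 nM in this assay.

Among the compounds with values here, on these two numbers compound 2 stands highest; its nearest neighbour is compound 1, and the only measured step, a 2.1-fold higher number from compound 1 to compound 2 (0.32 log units; beyond the scatter), separates the two. Compound 3, `O=C(Nc1cc2c(Nc3ccc(F)c(Cl)c3)ncnc2cc1O[C@H]1CCOC1)N1CC(O)C1`, has not yet been measured in this assay. It differs from compound 2 by a change at the carbonyl carbon: 3-hydroxyazetidin-1-yl in place of (2-(dimethylamino)ethyl)amino on a carbonyl carbon.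

Within the data shown here, only the step from compound 1 to compound 2 bears on this change, since it alters the same urea-type tail, and it was modest in size. Among the measured compounds shown here, the new group removes the (2-(dimethylamino)ethyl)amino tail that accompanied the higher number of compound 2, so a shift back toward the number of compound 1 is expected, though the hydroxyazetidine ring has no measured precedent here. Compound 3 is therefore estimated at 450 nM, within 200 nM to 1000 nM, which means an expected step of a 1.8-fold lower number from compound 2 to compound 3 (0.25 log units; within the scatter).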

Compound 3, half-maximal inhibitory concentration: 1930 nM
Estimate against measurement, compound 3: 4.3-fold (0.63 log units) below; measured number outside the range, above it.
By their numbers in this assay, from the lowest: compound 1; then compound 2; then compound 3.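

In this assay, putting 3-hydroxyazetidin-1-yl in place of (2-(dimethylamino)ethyl)amino on the carbonyl carbon gives a 2.4-fold higher number from compound 2 to compound 3 (0.38 log units; beyond the scatter), so removing the dimethylamino chain does not by itself bring the number back toward that of compound 1. Set against the (2-methoxyethyl)amino group, the same ring gives a 5.0-fold higher number from compound 1 to compound 3 (0.70 log units; beyond the scatter), and compound 3 therefore carries the highest number of the three, with its steps to both open-chain compounds printed as beyond the scatter; among these compounds, the one with a ring on this carbonyl carbon is the weakest inhibitor, while the two open-chain groups also differ from each other by a step beyond the scatter. No supporting measurement is available to explain why the ring compound gives the higher number.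

The three compounds cannot separate the contribution of the four-membered ring from that of its hydroxyl group, which the unsubstituted azetidin-1-yl group or the open-chain (2-hydroxyethyl)amino group would address. From the compounds shown here alone, whether larger rings on the carbonyl carbon, such as pyrrolidin-1-yl or morpholin-4-yl, follow the azetidine also remains open.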